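A few compounds are considered here, and "the series" means these few. Any claim that something is new, unique, unknown or untested is made for them only; others in the source may bear on it.

In a functional assay on KB cells (Homo sapiens) for inhibition, read by sulforhodamine B assay, with a stated time of 72 h (on this read-out higher numbers stand for weaker inhibition of growth and lower numbers for stronger inhibition of growth), compound 1 (`CCOC(=O)/C=C/c1ccncc1-c1ccc2ccccc2c1`) gives > 10000 nM, which is a limit of the assay and not a number. Compound 2 (`COC1CN(C(=O)/C=C/c2ccncc2-c2ccc3ccccc3c2)C1`) gives > 10000 nM, again a limit. Going by the values given here, compound 3 (`COC(=O)/C=C/c1ccncc1-c1ccc2ccccc2c1`) reads 6730 nM and holds the only actual number so far. The other readings stand at the limit of > 10000 nM in this assay, at which 2 of the 3 values shown sit.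

The step under consideration leads to compound 4 (`O=C(/C=C/c1ccncc1-c1ccc2ccccc2c1)NC1CC1`), with cyclopropylamino in place of methoxy on a carbonyl carbon.

Among the compounds with values here, two measured steps bear on this change. Compound 2 carries 3-methoxyazetidin-1-yl on that same carbonyl carbon, and the change to methoxy is an at least 1.4-fold lower number from compound 2 to compound 3 (0.17 log units; that floor lies within the scatter). The change from ethoxy to methoxy on the carbonyl side chain is an at least 1.4-fold lower number from compound 1 to compound 3 (0.17 log units; that floor lies within the scatter). The remaining pair gives a step that the two limits leave unreadable from compound 1 to compound 2 and adds nothing on size. Going by these compounds, both readable steps are only floors, so their true sizes stay open, and neither shows a change beyond the scatter.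

No step beyond the scatter is therefore expected in this assay, and the expected move is a 1.2-fold higher number from compound 3 to compound 4 (0.08 log units; within the scatter). A reading at the limit is about as likely as a number. For compound 4 the estimate is 8000 nM, with an expected range of 2500 nM to 20000 nM.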

Compound 4, concentration for 50% growth inhibition: 6050 nM
Estimate against measurement, compound 4: 1.3-fold (0.12 log units) above; the range from low to high includes it.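

Going by these compounds alone, replacing methoxy with cyclopropylamino on the carbonyl carbon gives a 1.1-fold lower number from compound 3 to compound 4 (0.05 log units; within the scatter) in this assay, the first step at this position with a number at both ends. At this level of growth inhibition, the position therefore accepts a group with a three-membered ring and a hydrogen-bond donor in place of one with neither, with no change that can be told from scatter. The steps to compound 4 from the two other compounds are floors, an at least 1.6-fold lower number from compound 2 to compound 4 (0.21 log units; that floor lies within the scatter) and an at least 1.6-fold lower number from compound 1 to compound 4 (0.21 log units; that floor lies within the scatter), so their true sizes stay open, and compound 1 and compound 2 each remain at a limit of the assay, not a number: the limit of > 10000 nM in this assay, at which 2 of the 4 values shown sit.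

Going by these compounds, whether a carboxylic acid, a dimethylamino group or a longer chain such as butylamino on this carbonyl carbon would give a step beyond the scatter stays open. The shared core is the same in every compound shown, and what a change there would do to the number in this assay also stays open.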